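Swapping the ring at the alkyne end: compound 2 to compound 3

The source may hold more compounds than are shown below. What is called first, only, known or untested is meant among the compounds shown, and "the series" means these compounds.

Two compounds share a core in which a propanoic acid chain sits on one benzene ring and a second aromatic ring hangs off a carbon-carbon triple bond. In an in vitro functional assay on 1321-N1 cells for agonist activity at Free fatty acid receptor 1 (Homo sapiens), read by fluorescence, spectrophotometry and calcium flux (on this read-out lower numbers stand for an effect already at smaller amounts and higher numbers for an effect only at larger amounts of compound), compound 1 `O=C(O)CCc1ccc(C#Cc2cccnc2)cc1` gives 6030 nM, and compound 2 `O=C(O)CCc1ccc(C#Cc2cncs2)cc1` gives 3890 nM. Among the compounds with values here, the only measured step, a 1.6-fold lower number from compound 1 to compound 2 (0.19 log units; within the scatter), exchanges one ring on the triple bond for another. Compound 2 stands at the lowest of the two numbers, but its distance to compound 1 lies within the scatter, so the two cannot be ordered.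

Compound 3 `Cc1ccsc1C#Cc1ccc(CCC(=O)O)cc1` is not yet measured. It differs from compound 2 by 3-methylthiophen-2-yl in place of 1,3-thiazol-5-yl on a triple-bonded carbon. The step from compound 1 to compound 2 is the only one that bears on this change, and it produced no shift beyond the scatter, so there is no measured basis for expecting a clear move in this assay here either. Compound 3 is therefore expected to give about 3000 nM, with a plausible range from 1000 nM to 9000 nM, a step of a 1.3-fold lower number from compound 2 to compound 3 (0.11 log units; within the scatter) that is expected to stay within the scatter.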

Compound 3, half-maximal effective concentration: 75.9 nM
For compound 3 the middle estimate is 40-fold (1.60 log units) above the measured one; measured number below the stated range.
By their numbers in this assay, from the lowest: compound 3; then compounds 2 and 1 (each within the scatter of the next).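

The ring on the triple-bonded carbon turns out to matter greatly in this assay. Placing 3-methylthiophen-2-yl there gives a 51-fold lower number from compound 2 to compound 3 (1.71 log units; beyond the scatter) and a 79-fold lower number from compound 1 to compound 3 (1.90 log units; beyond the scatter), both large, whereas the exchange of pyridin-3-yl for 1,3-thiazol-5-yl had produced no shift beyond the scatter. This step changes two things at once, as the ring loses its nitrogen and gains a methyl group, and no measurement shown here explains why the number falls so far.

The compounds shown leave open whether the methyl group, the thiophene ring or the two together account for the drop, and a plain thiophen-2-yl on the triple bond would begin to separate these contributions. They also leave open how much room this position allows, which an ethyl group or a chlorine in place of the methyl on the thiophene ring could test.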